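The source may hold more compounds than are shown below. What is called first, only, known or untested is meant among the compounds shown, and "the series" means these compounds.

Compound 1 `Cc1ccc(/C=N/N(C(=O)c2ccccc2)C(=O)c2ccncc2)cc1`: in an ADME assay on MT4 cells (Homo sapiens) for cytotoxicity (a lower number here means that less compound is tolerated, a higher number that more compound is tolerated), compound 1 gives 42 ug/mL.
Compound 2 `CSc1ccc(/C=N/N(C(=O)c2ccccc2)C(=O)c2ccncc2)cc1`: compound 2 gives 69 ug/mL.

On the numbers shown, compound 2 stands at the top of two, yet a 1.6-fold higher number from compound 1 to compound 2 (0.22 log units; within the scatter) lies within the scatter, so the two cannot be separated. Compound 3 `CSc1ccc(/C=N/NC(=O)c2ccncc2)cc1` differs from compound 2 by hydrogen in place of benzoyl on an amide-type nitrogen. Going by the values given here, the only measured step swaps a group on the aromatic ring and leaves the amide-type nitrogen untouched, so no measured step bears on this change. The expected step in this assay is therefore none beyond the scatter, in no set direction: a 1.2-fold lower number from compound 2 to compound 3 (0.06 log units; within the scatter). Compound 3 is estimated at 60 ug/mL, with a range from 25 ug/mL to 150 ug/mL.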

Compound 3, half-maximal cytotoxic concentration: 59 ug/mL
For compound 3 the middle estimate is 1.0-fold (0.01 log units) above the measured one; the range from low to high includes it.
By their numbers in this assay, from the lowest: compounds 1, 3 and 2 (each within the scatter of the next).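

Hydrogen in place of benzoyl on the amide-type nitrogen gives a 1.2-fold lower number from compound 2 to compound 3 (0.07 log units; within the scatter) in this assay. The whole benzoyl group can therefore leave this position with no difference that stands clear of the scatter, something the earlier step on the aromatic carbon could not show. No measurement at hand accounts for this result.

Still open, going by these compounds, is whether other groups on this nitrogen, such as acetyl or a longer alkyl chain, would also fall within the scatter. On these data alone, it is equally open whether the same change would read alike with the methyl of compound 1 in place of methylsulfanyl.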